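Aryl amine variation across three measured compounds, one pending

The source may hold more compounds than are shown below. What is called first, only, known or untested is meant among the compounds shown, and "the series" means these compounds.

Compound 1 `COc1cc2ncnc(Nc3ccc(Cl)c(C(F)(F)F)c3)c2cc1OCCCCC(=O)Nc1ccc(S(N)(=O)=O)cc1` gives 9270 nM in a functional assay on A549 cells (Homo sapiens) for antiproliferative activity, read by MTT assay, with a stated time of 72 h; a lower number here means a stronger inhibitor, a higher number a weaker inhibitor.
Compound 2 `COc1cc2ncnc(Nc3ccc(F)c(Br)c3)c2cc1OCCCCC(=O)Nc1ccc(S(N)(=O)=O)cc1` gives 16000 nM in this assay.
Compound 3 `COc1cc2ncnc(Nc3cccc(Cl)c3F)c2cc1OCCCCC(=O)Nc1ccc(S(N)(=O)=O)cc1` gives 10500 nM in this assay.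

Compound 1 carries the lowest of the three numbers, but neither of its steps to the others leaves the scatter: a 1.7-fold higher number from compound 1 to compound 2 (0.24 log units; within the scatter) and a 1.1-fold higher number from compound 1 to compound 3 (0.05 log units; within the scatter). The remaining pair behaves the same way, a 1.5-fold lower number from compound 2 to compound 3 (0.18 log units; within the scatter). Across the three aryl groups on the ring nitrogen, this assay therefore shows no separation that can be read as a trend.

Compound 4 `COc1cc2ncnc(Nc3ccc(OC(F)(F)F)cc3)c2cc1OCCCCC(=O)Nc1ccc(S(N)(=O)=O)cc1` differs from compound 1 by 4-(trifluoromethoxy)phenyl in place of 4-chloro-3-(trifluoromethyl)phenyl on a nitrogen on an aromatic ring. For the measured compounds named here, no measured step covers a 4-(trifluoromethoxy)phenyl at this position, so the only guidance is that the three steps exchanging the same aryl group all stayed within the scatter. On that basis no step beyond the scatter is expected in either direction. Compound 4 is estimated at 12000 nM in this assay, with a range from 5000 nM to 30000 nM. This estimate corresponds to an expected step of a 1.3-fold higher number from compound 1 to compound 4 (0.11 log units; within the scatter), inside the scatter.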

Compound 4, half-maximal inhibitory concentration: > 40000 nM
Compound 4: only a limit was reported; the forecaster's own chance of this, stated with the estimate: 10%; at least 3.3-fold (0.52 log units) between middle value and limit.
By their numbers in this assay, from the lowest: compounds 1, 3 and 2 (each within the scatter of the next). At a limit, above all of these: compound 4.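

The reading for compound 4 is a limit, not a number: the limit of > 40000 nM in this assay, at which 1 of the 4 values shown sits. In this assay, for the compounds shown here, this position now separates for the first time, with each step beyond the scatter: an at least 4.3-fold higher number from compound 1 to compound 4 (0.63 log units; beyond the scatter), an at least 3.8-fold higher number from compound 3 to compound 4 (0.58 log units; beyond the scatter) and an at least 2.5-fold higher number from compound 2 to compound 4 (0.39 log units; beyond the scatter). The aryl group on this nitrogen therefore does matter: the three earlier groups cannot be told apart, while 4-(trifluoromethoxy)phenyl stands clearly apart from all of them, even though it has as many heavy atoms as the 4-chloro-3-(trifluoromethyl)phenyl it replaces.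

The limit leaves the full size of these steps open. Also open, from the compounds shown here alone, is whether the oxygen of the trifluoromethoxy group or the loss of the chlorine-bearing pattern goes with the drop, a question that a 4-(trifluoromethyl)phenyl or a 4-chlorophenyl on the same nitrogen would address.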